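This account rests on a few compounds, and the source may have more. Where it says the series, first, only, none or still open, it means among the compounds named here.

Three compounds share one core and differ only in the aryl group attached to an aromatic carbon of that core. Compound 1 `CCOC(=O)CCCCCOc1cccc(CN(C(=O)c2ccc(-c3cnc(OC)nc3OC)cc2)C(C)C)c1` carries 2,4-dimethoxypyrimidin-5-yl there. In an ADME assay on Raji cells (Homo sapiens) for cytotoxicity, read by CellTiter-Glo and resazurin assay, with a stated time of 72 h (a higher number here means that more compound is needed for the effect, a lower number that less compound is needed), compound 1 gives only a limit, > 26000 nM. Compound 2 `CCOC(=O)CCCCCOc1cccc(CN(C(=O)c2ccc(-c3cccc(OC(C)C)c3)cc2)C(C)C)c1` carries 3-isopropoxyphenyl. In this assay compound 2 likewise gives only a limit, > 26000 nM. Compound 3 `CCOC(=O)CCCCCOc1cccc(CN(C(=O)c2ccc(-c3ccco3)cc2)C(C)C)c1` carries furan-2-yl. In this assay compound 3 also gives only a limit, > 26000 nM. Going by the values given here, because every value sits at the limit of > 26000 nM in this assay, at which 3 of the 3 values shown sit, no step among the three can be sized: a step that the two limits leave unreadable from compound 1 to compound 2, a step that the two limits leave unreadable from compound 1 to compound 3 and a step that the two limits leave unreadable from compound 2 to compound 3 are all unreadable. Compound 3 therefore stands nowhere that the numbers can fix; it is one of three limits, indistinguishable from its neighbours.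

Compound 4 `CCOC(=O)CCCCCOc1cccc(CN(C(=O)c2ccc(-c3ccc4c(c3)OCCO4)cc2)C(C)C)c1` has not yet been measured. It differs from compound 3 by 2,3-dihydro-1,4-benzodioxin-6-yl in place of furan-2-yl on an aromatic carbon. The three unreadable steps are the only ones that bear on this kind of exchange, and each of them swapped one aryl group for another at the same aromatic carbon without bringing any compound into the readable range. The writer therefore expects no step beyond the scatter, with a step that the limit leaves unreadable from compound 3 to compound 4 as the nominal expectation. Compound 4 is accordingly estimated at 30000 nM, within 15000 nM to 80000 nM, most probably reported once more as a limit.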

Compound 4, half-maximal effective concentration: > 24400 nM
Compound 4 ended at the assay's limit; the forecaster's own chance of this, stated with the estimate: 80%; the middle value lies beyond the limit too.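

In this assay compound 4 gives only a limit, > 24400 nM. Going by these compounds alone, compound 1, compound 2 and compound 3 also give only limits, so no step linking them to compound 4 can be read. The compounds shown leave open whether any aryl group at this aromatic carbon would give the shared core a measurable value in this assay.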